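A few compounds are considered here, and "the series" means these few. Any claim that something is new, unique, unknown or untested is made for them only; others in the source may bear on it.

Measured compounds:
Compound 1 `CCc1ccc(CCCCCCCCC(N)(CO)CO)cc1` — > 3 mg/kg
Compound 2 `CCCCCCCCCc1ccc(CCC(N)(CO)CO)cc1` — 0.03 mg/kg

Both values come from a functional assay on the whole organism with Rattus norvegicus as the target; on this read-out lower numbers stand for an effect already at smaller amounts and higher numbers for an effect only at larger amounts of compound. For compound 1 the value > 3 mg/kg is a limit of the measurement and not a number. It sits at the limit of > 3 mg/kg in this assay, at which 1 of the 2 values shown sits. Among the measured compounds shown here, compound 2 with 0.03 mg/kg is the only number reported in this assay. For the measured compounds named here, because the other value is not a number, no step between the two can be sized.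

The unmeasured compound 3 `CCCCCCCCCCCCCCc1ccc(CCC(N)(CO)CO)cc1` shares the core of compound 2 and differs by pentyl in place of hydrogen on a saturated chain carbon, nine bonds along the chain from an aromatic carbon. Going by the values given here, no measured step of this kind exists, so the size of the change can only be guessed. A modest loss of potency in this assay, somewhat beyond the scatter, is expected; the step of a 3.3-fold higher number from compound 2 to compound 3 (0.52 log units; beyond the scatter) is the estimated outcome. Compound 3 is expected to give 0.1 mg/kg, with a range of 0.02 mg/kg to 0.6 mg/kg.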

Compound 3, dose for 50% inhibition: 1 mg/kg
Compound 3: middle estimate off by 10-fold (1.00 log units), on the low side, outside the stated range (above it).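

Among the compounds shown here, the saturated chain carbon nine bonds along the chain from an aromatic carbon is sensitive to substitution in this assay: pentyl in place of hydrogen there gives a 33-fold higher number from compound 2 to compound 3 (1.52 log units; beyond the scatter), the first step that can be sized. Compound 3 still gives a number, 1 mg/kg, and not a limit, so this change leaves an effect that can be read on this scale. Nothing measured here accounts for the size of the step.

Compound 1 gives > 3 mg/kg, which is a limit and not a number, so steps to it cannot be read. Open, from the compounds shown here alone, is how the value moves with butyl, a longer chain or a carboxylic acid in place of hydrogen on that same carbon, and so whether potency falls steadily with added chain or drops abruptly.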